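This account rests on a few compounds, and the source may have more. Where it says the series, first, only, none or still open, it means among the compounds named here.

Working notes on the aryl sulfonate series. In a functional assay on MCF7 cells (Homo sapiens) for antiproliferative activity, read by sulforhodamine B assay, with a stated time of 48 h (on this read-out higher numbers stand for weaker inhibition and lower numbers for stronger inhibition), compound 1 `COc1ccccc1OS(=O)(=O)c1ccc(N2CCN(C)C2=O)cc1` gives 26000 nM, compound 2 `Cc1ccc(OS(=O)(=O)c2ccc(N3CCN(C)C3=O)cc2)c(C)c1` gives 2500 nM and compound 3 `CN1CCN(c2ccc(S(=O)(=O)Oc3cccc(I)c3)cc2)C1=O` gives 560 nM. Compound 3 is therefore the lowest of the three numbers, with both gaps to the others beyond the scatter.

The next analogue is compound 4 `CN1CCN(c2ccc(S(=O)(=O)Oc3ccc(Cl)cc3)cc2)C1=O`, unmeasured so far. The change is 4-chlorophenyl in place of 3-iodophenyl on an oxygen, with the rest of the structure shared.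

All three measured steps bear on it, since each swaps the group at this same oxygen: a 10-fold lower number from compound 1 to compound 2 (1.02 log units; beyond the scatter), a 46-fold lower number from compound 1 to compound 3 (1.67 log units; beyond the scatter) and a 4.5-fold lower number from compound 2 to compound 3 (0.65 log units; beyond the scatter). These show that the group at this place can move the number well beyond the scatter. None of them involves the 4-chlorophenyl group, so the direction rests on weak evidence. Within the data shown here, with compound 3 at 560 nM as the lowest number so far, a move upward seems more likely than a further drop.

In this assay, the expected change is modest, and a 2.7-fold higher number from compound 3 to compound 4 (0.43 log units; beyond the scatter) is the estimated step. For compound 4 the estimated value is 1500 nM, with an expected range of 400 nM to 6000 nM.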

Compound 4, half-maximal inhibitory concentration: > 100000 nM
Compound 4: a limit, no number; the forecaster's own chance of this, stated with the estimate: 3%; at least 66-fold (1.82 log units) between middle value and limit.
By their numbers in this assay, from the lowest: compound 3; then compound 2; then compound 1. At a limit, above all of these: compound 4.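

In this assay compound 4 carries a limit of the assay and not a number: the limit of > 100000 nM in this assay, at which 1 of the 4 values shown sits.

Among these compounds, exchanging 3-iodophenyl for 4-chlorophenyl at this oxygen gives an at least 170-fold higher number from compound 3 to compound 4 (2.25 log units; beyond the scatter), the largest step so far, although the two groups match in what is counted here, and so those counts do not track the read-out across this pair. The other two steps, an at least 40-fold higher number from compound 2 to compound 4 (1.60 log units; beyond the scatter) and an at least 3.8-fold higher number from compound 1 to compound 4 (0.58 log units; beyond the scatter), also put compound 4 past compound 1, which held the highest number until now, so the group on this oxygen can take the read-out out of the measurable range and not merely shift it within the earlier spread.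

The compounds shown leave open whether the step follows the change of halogen or where it sits on the ring, as neither 3-chlorophenyl nor 4-iodophenyl is among them to divide the two. On these data alone, how far a 3-aminophenyl or 3-carboxyphenyl group on this oxygen would carry the number from that of compound 3 also remains open.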